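Methylsulfanyl for methylamino on the fused dione core

This account rests on a few compounds, and the source may have more. Where it says the series, first, only, none or still open, it means among the compounds named here.

Measured compounds:
compound 1 `CNC1=C(SC)C(=O)c2ncccc2C1=O` — 3440 nM
compound 2 `CNC1=C(SC)C(=O)c2cccnc2C1=O` — 7920 nM

Going by the values given here, in a functional assay on HL-60 cells (Homo sapiens) for antiproliferative activity, read by MTT assay, with a stated time of 48 h (a lower number here means a stronger inhibitor, a higher number a weaker inhibitor), compound 2 gives 7920 nM, the higher of the two numbers measured so far; compound 1, the only other compound, gives 3440 nM in this assay, and the gap between the two lies beyond the usual scatter. Among the compounds with values here, compounds 1 and 2 differ only in the position of the ring nitrogen in their shared core, so no step has been measured that bears on a substituent change.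

Compound 3 `CSC1=C(SC)C(=O)c2ncccc2C1=O`, not yet measured, differs from compound 2 by methylsulfanyl in place of methylamino on a double-bonded ring carbon. Within the data shown here, the series holds no measured pair that swaps a methylamino for a methylsulfanyl, so no size for this step can be read from the data. In the absence of such a pair, compound 3 is expected to stay close to compound 2 in this assay, with the step from compound 2 to compound 3 estimated at a 1.0-fold higher number from compound 2 to compound 3 (0.00 log units; within the scatter), a change not beyond the scatter in either direction. Compound 3 is therefore estimated at 8000 nM, within a wide range from 2500 nM to 25000 nM.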

Compound 3, half-maximal inhibitory concentration: 1230 nM
Beside the measured number, compound 3's estimate is 6.5-fold (0.81 log units) above it; measured number outside the range, below it.
By their numbers in this assay, from the lowest: compound 3; then compound 1; then compound 2.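

In this assay, the double-bonded ring carbon proves sensitive to this exchange: on the core shared by compound 1 and compound 3, methylsulfanyl in place of methylamino gives a 2.8-fold lower number from compound 1 to compound 3 (0.45 log units; beyond the scatter). This is the cleanest reading of the change, and it shows that the hydrogen-bond donor of methylamino is not required for activity at this position in this cell assay. Compound 1 and compound 2 differ in the position of the ring nitrogen. That shift also lies within the larger 6.4-fold lower number from compound 2 to compound 3 (0.81 log units; beyond the scatter), so this step cannot be read as the exchange alone. Nothing at hand accounts for the direction or size of either step.

The compounds shown leave open whether the same exchange would bring a similar step on the core of compound 2, where only methylamino appears at this position. They also leave open whether the lower number follows sulfur itself or the absence of the amine hydrogen, a question that methoxy, dimethylamino or a longer chain such as ethylsulfanyl at this position could help to separate.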